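Removing the ethyl group from the anilino ring

The source may hold more compounds than are shown below. What is called first, only, known or untested is meant among the compounds shown, and "the series" means these compounds.

Compound 2 `CCc1ccc(Nc2ncnc3cc(OC)c(OCCCCC(=O)Nc4ccc(S(N)(=O)=O)cc4)cc23)cc1`: 7220 nM
Compound 1 `C#Cc1cccc(Nc2ncnc3cc(OC)c(OCCCCC(=O)Nc4ccc(S(N)(=O)=O)cc4)cc23)c1`: 17700 nM

In a functional assay on A-431 cells (Homo sapiens) for antiproliferative activity, read by MTT assay, with a stated time of 72 h (a higher number here means a weaker inhibitor, a lower number a stronger inhibitor), compound 2 gives the lowest of the two numbers shown, and its nearest neighbour compound 1 gives 17700 nM, which is a 2.5-fold lower number from compound 1 to compound 2 (0.39 log units; beyond the scatter). Compound 3 `COc1cc2ncnc(Nc3ccccc3)c2cc1OCCCCC(=O)Nc1ccc(S(N)(=O)=O)cc1` differs from compound 2 by hydrogen in place of ethyl on an aromatic carbon. For the measured compounds named here, no measured step matches this change: the only step on record swaps the whole substituted aryl group rather than stripping a substituent, so it offers no direct guide. A modest rise or no step beyond the scatter is expected, a 2.1-fold higher number from compound 2 to compound 3 (0.32 log units; beyond the scatter). Compound 3 is therefore estimated at 15000 nM, within 5000 nM to 45000 nM.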

Compound 3, half-maximal inhibitory concentration: 25200 nM
Compound 3: middle estimate off by 1.7-fold (0.23 log units), on the low side, within the range that was stated.
By their numbers in this assay, from the lowest: compound 2; then compounds 1 and 3 (each within the scatter of the next).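

In this assay, removing the ethyl group alone gives a 3.5-fold higher number from compound 2 to compound 3 (0.54 log units; beyond the scatter), so the ethyl group itself, not just the swap of the whole aryl group, separates compound 2 from the unsubstituted phenyl. Hydrogen in place of ethynyl gives a 1.4-fold higher number from compound 1 to compound 3 (0.15 log units; within the scatter), so the ethynyl group of compound 1 shows no such separation from hydrogen. Nothing available explains this difference. From the compounds shown here alone, whether a propyl group, a methoxy group or an amine in place of the ethyl group would take the number lower than in compound 2 remains open.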